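Fluorine on the pyridine ring: exposure of compound 3

The source may report more compounds than this note shows. Statements on the series, on what has been measured and on what is new or still open speak of the compounds shown alone.

This account follows a series sharing one core, measured in an ADME assay on the whole organism for pharmacokinetics, with Rattus norvegicus as the target, with a stated time of 6 h, at a dose of 10 mg/kg by the oral route; on this read-out higher numbers stand for higher exposure at the dose given and lower numbers for lower exposure. Compound 1 `Cc1cn2c(-c3cn[nH]c3)cnc2c(Nc2cc(Cc3ncccn3)ns2)n1` gives 701 ng.h/mL. Compound 2 `Cc1cn2c(-c3cn[nH]c3)cnc2c(Nc2cc(Cc3ccccn3)ns2)n1` gives 6880 ng.h/mL, the highest of the two numbers recorded; the step of a 9.8-fold higher number from compound 1 to compound 2 (0.99 log units; beyond the scatter) sets it apart from its nearest neighbour. Compound 3 `Cc1cn2c(-c3cn[nH]c3)cnc2c(Nc2cc(Cc3ncccc3F)ns2)n1` has not yet been measured. It differs from compound 2 by fluoro in place of hydrogen on an aromatic carbon. Within the data shown here, no measured step involves a fluoro group, so the only step available, a 9.8-fold higher number from compound 1 to compound 2 (0.99 log units; beyond the scatter), concerns a different change and offers no direct guide to this one. With nothing in the data pointing in either direction, compound 3 is expected to sit close to compound 2 in this assay, a step of a 1.1-fold lower number from compound 2 to compound 3 (0.06 log units; within the scatter) that stays within the scatter. The estimate for compound 3 is therefore 6000 ng.h/mL, with a range from 2500 ng.h/mL to 15000 ng.h/mL.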

Compound 3, area under the concentration-time curve: 569 ng.h/mL
The estimate for compound 3 lay 11-fold (1.02 log units) above the measured number; measured number outside the range, below it.
By their numbers in this assay, from the lowest: compounds 3 and 1 (each within the scatter of the next); then compound 2.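

In this assay, a single fluoro on an aromatic carbon two atoms from the ring nitrogen, ortho to a large group, proves far from a neutral change: it gives a 12-fold lower number from compound 2 to compound 3 (1.08 log units; beyond the scatter), a large step for one heavy atom. Set against the pyrimidin-2-yl compound, the 3-fluoropyridin-2-yl compound shows a 1.2-fold lower number from compound 1 to compound 3 (0.09 log units; within the scatter), so the advantage of the pyridin-2-yl group in compound 2 does not survive this one substitution. Nothing measured here accounts for this loss of exposure.

As far as these compounds go, whether the drop belongs to fluoro itself or to this place on the ring stays open. So does whether a chloro or a methoxy group on the same carbon, or a fluoro on another carbon of the pyridine ring, would give the same low exposure.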